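The compounds below may be only part of what the source reports. "The series", "measured", "known", "first", "only" and "open" are said of these compounds alone.

For the measured compounds named here, compound 3 `CN(C[C@H]1Cc2c(cccc2N2CCN3CCC[C@@H]3C2)CN1)[C@H]1CCCc2cccnc21` gives 3.59 nM in a functional assay on CCRF-CEM cells for antagonist activity at C-X-C chemokine receptor type 4 (Homo sapiens), read by calcium flux, with stated times of 25 min and 90 s (a higher number here means a weaker inhibitor, a lower number a stronger inhibitor), the second highest of the three numbers so far. Compound 2 `CN(C[C@H]1Cc2c(cccc2N2CCN3CCC[C@H]3C2)CN1)[C@H]1CCCc2cccnc21` gives 2.92 nM, and a 1.2-fold higher number from compound 2 to compound 3 (0.09 log units; within the scatter) lies within the scatter, which fits (the fact that compounds 2 and 3 differ only in the configuration as drawn). Compound 1 `CN(C[C@H]1Cc2c(cccc2N2CCN(C3CC3)CC2)CN1)[C@H]1CCCc2cccnc21` gives 23.5 nM; the steps are an 8.0-fold lower number from compound 1 to compound 2 (0.91 log units; beyond the scatter) and a 6.5-fold lower number from compound 1 to compound 3 (0.82 log units; beyond the scatter), so both bicyclic amines gave clearly lower numbers than the cyclopropylpiperazine.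

Compound 4 `C[C@@H]1CN(c2cccc3c2C[C@H](CN(C)[C@H]2CCCc4cccnc42)NC3)C[C@H](C)N1C` carries a group of 9 heavy atoms (7 carbon, 2 nitrogen; one six-membered non-aromatic ring with 2 hetero atoms) in place of a group of 9 heavy atoms (7 carbon, 2 nitrogen; one five-membered non-aromatic ring with 1 hetero atom, one six-membered non-aromatic ring with 2 hetero atoms), on an aromatic carbon. Going by the values given here, no measured step covers this exact exchange; the nearest evidence, a 6.5-fold lower number from compound 1 to compound 3 (0.82 log units; beyond the scatter), shows that replacing a monocyclic piperazine by the bicycle lowered the number, so returning to a monocyclic piperazine, now trimethylated, is expected to move the number back up, by a modest amount. For compound 4 in this assay the estimate is 10 nM, range 3 nM to 35 nM, a step of a 2.8-fold higher number from compound 3 to compound 4 (0.44 log units; beyond the scatter) expected.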

Compound 4, half-maximal inhibitory concentration: 14.1 nM
The estimate for compound 4 lay 1.4-fold (0.15 log units) below the measured number; low and high end bracket the measured number.
By their numbers in this assay, from the lowest: compounds 2 and 3 (each within the scatter of the next); then compounds 4 and 1 (each within the scatter of the next).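

At this aromatic carbon, 3,4,5-trimethylpiperazin-1-yl does not hold the level of the fused bicyclic amines, with a 3.9-fold higher number from compound 3 to compound 4 (0.59 log units; beyond the scatter) and a 4.8-fold higher number from compound 2 to compound 4 (0.68 log units; beyond the scatter) on the same core. Against the other monocyclic piperazine, a 1.7-fold lower number from compound 1 to compound 4 (0.22 log units; within the scatter) separates the trimethyl and 4-cyclopropyl groups by no more than usual variation, so both monocyclic compounds read above both bicyclic compounds. The compounds shown give no measured basis for explaining this difference.

Open, from the compounds shown here alone, is whether the fused five-membered ring itself matters, and how a piperazine bearing a hydroxyethyl chain or a primary amine would read at this carbon.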